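The source may hold more compounds than are shown below. What is called first, only, known or untested is meant among the compounds shown, and "the series" means these compounds.

Three compounds of a shared core have numbers in a functional assay on HeLa cells (Homo sapiens) for cytotoxicity, read by MTT assay, with a stated time of 48 h; a higher number here means a weaker inhibitor, a lower number a stronger inhibitor. Compound 1 `COc1ccccc1C(C1=C(O)C(=O)c2ccccc2C1=O)c1c[nH]c2ccccc12` gives 128000 nM; compound 2 `O=C1C(O)=C(C(c2ccc([N+](=O)[O-])cc2)c2c[nH]c3ccccc23)C(=O)c2ccccc21` gives 14800 nM; compound 3 `O=C1C(O)=C(C(c2ccc(Cl)cc2)c2c[nH]c3ccccc23)C(=O)c2ccccc21` gives 37000 nM. Compound 3 thus stands second highest of the three, nearer to compound 2 than to compound 1. The unmeasured compound 4 `O=C1C(O)=C(C(c2cccc([N+](=O)[O-])c2)c2c[nH]c3ccccc23)C(=O)c2ccccc21` differs from compound 3 by 3-nitrophenyl in place of 4-chlorophenyl on a saturated chain carbon bound to an aromatic carbon and a double-bonded ring carbon. The step bearing most directly on this is a 2.5-fold higher number from compound 2 to compound 3 (0.40 log units; beyond the scatter), a modest change on a single aromatic carbon, though there the nitro group sat on a 4-nitrophenyl rather than a 3-nitrophenyl. Reversing it, one expects a modestly lower number for compound 4, estimated at 18000 nM with a range of 7000 nM to 50000 nM, which would mean a 2.1-fold lower number from compound 3 to compound 4 (0.31 log units; beyond the scatter).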

Compound 4, half-maximal inhibitory concentration: 24900 nM
For compound 4 the middle estimate is 1.4-fold (0.14 log units) below the measured one; the measured number falls inside the stated range.
By their numbers in this assay, from the lowest: compounds 2, 4 and 3 (each within the scatter of the next, the first and the last beyond it); then compound 1.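

In this assay, 3-nitrophenyl on this saturated chain carbon cannot be told apart from 4-chlorophenyl, with a 1.5-fold lower number from compound 3 to compound 4 (0.17 log units; within the scatter), or from 4-nitrophenyl, with a 1.7-fold higher number from compound 2 to compound 4 (0.23 log units; within the scatter). Shifting the nitro group around the ring therefore gives no difference beyond the scatter, while 3-nitrophenyl stays clearly apart from 2-methoxyphenyl, with a 5.1-fold lower number from compound 1 to compound 4 (0.71 log units; beyond the scatter). Nothing available explains these numbers. Still open, from the compounds shown here alone, is how an amine or a carboxylic acid on this aryl ring would read. Also open, going by these compounds, is whether the gap to 2-methoxyphenyl follows the methoxy group itself or its place, which a 4-methoxyphenyl compound would separate.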